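Thiophen-2-yl in place of 4-methylphenyl: working notes

This account rests on a few compounds, and the source may have more. Where it says the series, first, only, none or still open, it means among the compounds named here.

In a functional assay on 1A9 cells (Homo sapiens) for cytotoxicity (a lower number here means that less compound is needed, a higher number that more compound is needed for the effect), compound 1 (`COC1=C(C)C(=O)/C(=C(O)/C=C/c2ccc(C)cc2)C(=O)C1(C)C`) gives "not determined" (no result reported) and so has no number to stand on. Compound 3 (`COC1=C(C)C(=O)/C(=C(O)/C=C/c2cccc3ccccc23)C(=O)C1(C)C`) also gives "not determined" (no result reported) and adds no comparison. Among the measured compounds shown here, the single number comes from compound 2 (`COC1=C(C)C(=O)/C(=C(O)/C=C/c2c(C)cc(C)cc2C)C(=O)C1(C)C`) at 6.2 ug/mL in this assay and serves as the only anchor. Compound 4 (`COC1=C(C)C(=O)/C(=C(O)/C=C/c2cccs2)C(=O)C1(C)C`) has thiophen-2-yl in place of 4-methylphenyl on a double-bonded chain carbon bound to a double-bonded chain carbon. For the measured compounds named here, no step between measured compounds sizes this change, so no direction can be read and no step beyond the scatter is expected. Compound 4 is estimated at 6 ug/mL with an expected range of 2 ug/mL to 18 ug/mL in this series.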

Compound 4, concentration for half-maximal effect: 4 ug/mL
Beside the measured number, compound 4's estimate is 1.5-fold (0.18 log units) above it, within the range that was stated.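

No new step can be read for compound 4, as compound 1 and compound 3 carry no number in this assay to set against it. The compounds shown leave open how thiophen-2-yl compares with 4-methylphenyl at this place. No measurement at hand bears on the result.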